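Swapping an Aldehyde-Derived Ring on a Shared Thiazole Hydrazone Core

A few compounds are considered here, and "the series" means these few. Any claim that something is new, unique, unknown or untested is made for them only; others in the source may bear on it.

Compound 1 `COC(=O)c1cc(-c2csc(N/N=C/c3cccs3)n2)ccc1OCc1ccccc1`: 29.2 ug/mL
Compound 2 `Fc1ccc(-c2csc(N/N=C/c3ccc(Cl)cc3Cl)n2)cc1`: 35.5 ug/mL
Compound 3 `Fc1ccc(-c2csc(N/N=C/c3cccs3)n2)cc1`: 35.2 ug/mL

In a functional assay, read by spectrophotometry (on this read-out higher numbers stand for weaker inhibition and lower numbers for stronger inhibition), compound 1 gives 29.2 ug/mL, and its number sits together with those of compound 2 and compound 3, all three within the usual scatter of one another. Going by the values given here, no single-change pair among the measured compounds is available, but compound 2 and compound 3 share one core and differ only in the ring attached to the imine carbon; their numbers show no separation beyond the scatter.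

Compound 4 `COC(=O)c1cc(-c2csc(N/N=C/c3ccc(Cl)cc3Cl)n2)ccc1OCc1ccccc1` has not been measured. It differs from compound 1 by 2,4-dichlorophenyl in place of thiophen-2-yl on a carbon with a double bond to nitrogen. Given what compound 2 and compound 3 show, the step from compound 1 to compound 4 is expected to be a 1.0-fold higher number from compound 1 to compound 4 (0.01 log units; within the scatter), none beyond the scatter. Compound 4 is estimated at 30 ug/mL in this assay, within a range from 17 ug/mL to 52 ug/mL.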

Compound 4, half-maximal inhibitory concentration: 57.9 ug/mL
Compound 4: middle estimate off by 1.9-fold (0.29 log units), on the low side, and the stated range ends below it.
By their numbers in this assay, from the lowest: compounds 1, 3, 2 and 4 (each within the scatter of the next).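

In this assay the single change of 2,4-dichlorophenyl in place of thiophen-2-yl on the core of compound 1 gives a 2.0-fold higher number from compound 1 to compound 4 (0.30 log units; within the scatter) and so offers the first listed step at this carbon. On this core, the position accepts either ring without a step beyond the scatter. Nothing available explains the size of this step.

From the compounds shown here alone, whether an unsubstituted phenyl ring, or a ring bearing an amine or a carboxylic acid, would move the number beyond the scatter remains open.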